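The source may report more compounds than this note shows. Statements on the series, on what has been measured and on what is new or still open speak of the compounds shown alone.

Compound 2, `O=C1C(O)=C(O)OC2CCCCC12`, was examined in a functional assay for inhibition, with Homo sapiens as the target (on this read-out lower numbers stand for stronger inhibition and higher numbers for weaker inhibition), where compound 2 gives 447000 nM. Among the measured compounds shown here, of the two compounds measured so far, compound 2 shows the lower number, and the gap to its nearest neighbour lies beyond the usual scatter of this assay. That neighbour is compound 1, `O=c1c(O)c(O)oc2ccc(O)cc12`, a compound with an aromatic ring in place of the saturated ring of compound 2; in this assay compound 1 gives 1420000 nM.

The account now turns to compound 3, `O=C1C(O)=C(O)OC2CCCC[C@H]12`, which has not yet been measured in this assay. Its relation to compound 2 is the following: the two compounds have the same atoms and bonds; at least one stereo element is drawn with a configuration in one of them and without one in the other: 1 of 2 stereo elements differ; a stereocentre at a saturated ring carbon is drawn without a configuration in compound 2 and S in compound 3. In words, the two compounds have the same atoms and bonds, and one stereo element differs, a stereocentre at a saturated ring carbon drawn without a configuration in compound 2 and S in compound 3.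

For the measured compounds named here, since no step between two measured compounds exists that would show what fixing a configuration does here, the direction cannot be read from earlier numbers. Compound 3 is therefore expected to land close to compound 2, and the step of a 1.3-fold lower number from compound 2 to compound 3 (0.11 log units; within the scatter) is estimated to stay within the scatter, leaning toward a slightly lower number. For compound 3 the estimate in this assay is 350000 nM, with a range from 120000 nM to 1000000 nM.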

Compound 3, half-maximal inhibitory concentration: 481000 nM
Beside the measured number, compound 3's estimate is 1.4-fold (0.14 log units) below it; low and high end bracket the measured number.
By their numbers in this assay, from the lowest: compounds 2 and 3 (each within the scatter of the next); then compound 1.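

In this assay, drawing the S configuration at this saturated ring carbon gives a 1.1-fold higher number from compound 2 to compound 3 (0.03 log units; within the scatter). Among the compounds shown here, this is the first evidence on the stereocentre, since the earlier pair, compound 1 and compound 2, differ in their ring and say nothing about configuration; here, with atoms and bonds the same, fixing this one stereo element produces no difference that can be told apart from the scatter of the assay. The reading holds only for a centre drawn with a configuration set against the same centre drawn without one, and it does not compare two defined configurations, a limit that comes from the structures themselves: the fact that one of compounds 2 and 3 is drawn with a defined configuration and the other without, at the place where they differ

The compounds shown leave open how the R configuration at this carbon would read, and what the second stereo element, which is not the one that differs here, contributes to the number. They also leave open whether a substituent on the saturated ring, such as an amine or a carboxylic acid, would shift the number beyond the scatter, which the stereo step alone cannot indicate.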